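A few compounds are considered here, and "the series" means these few. Any claim that something is new, unique, unknown or untested is made for them only; others in the source may bear on it.

Among the measured compounds shown here, in a functional assay (Pituitary gland cell) with Rattus norvegicus as the target (a lower number here means that less compound is needed, a higher number that more compound is needed for the effect), compound 2 `C[C@@H](O)CCNC(C)(C)CC(=O)N[C@@H]1CCc2ccccc2N(Cc2ccc(-c3ccccc3-c3nn[nH]n3)cc2)C1=O` gives 10 nM, the lowest of the two numbers so far, while compound 1 `CC(C)(CC(=O)N[C@@H]1CCc2ccccc2N(Cc2ccc(-c3ccccc3-c3nn[nH]n3)cc2)C1=O)NC[C@H](O)[C@@H](O)CO` gives 40 nM. For the measured compounds named here, the single measured step, a 4.0-fold lower number from compound 1 to compound 2 (0.60 log units; beyond the scatter), came with 2-hydroxypropyl in place of 1,2,3-trihydroxypropyl on a saturated chain carbon bound to an amine nitrogen. Compound 3 `CCCNC(C)(C)CC(=O)N[C@@H]1CCc2ccccc2N(Cc2ccc(-c3ccccc3-c3nn[nH]n3)cc2)C1=O` carries the change (methyl in place of 1-hydroxyethyl on a saturated chain carbon, two bonds along the chain from an amine nitrogen). Both changes strip hydroxyl from the same chain, so the step expected here in the same direction is a 1.7-fold lower number from compound 2 to compound 3 (0.22 log units; within the scatter). Compound 3 is therefore estimated at 6 nM, within 2 nM to 20 nM.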

Compound 3, concentration for half-maximal effect: 50 nM
Estimate against measurement, compound 3: 8.3-fold (0.92 log units) below; the whole stated range lies below it.
By their numbers in this assay, from the lowest: compound 2; then compounds 1 and 3 (each within the scatter of the next).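

Along this chain, in this assay, the number does not simply fall as hydroxyl is removed: 1-hydroxyethyl to methyl gives a 5.0-fold higher number from compound 2 to compound 3 (0.70 log units; beyond the scatter), so the lowest number so far belongs to the chain with the single hydroxyl. Ethyl in place of 1,2,3-trihydroxypropyl gives a 1.3-fold higher number from compound 1 to compound 3 (0.10 log units; within the scatter), leaving the chains of compound 1 and compound 3 unseparated. No supporting data explain this reversal. Still open, going by these compounds, is whether an amine or a carboxylic acid could stand in place of the hydroxyl of compound 2. Also open, on these data alone, is how a longer chain carrying that hydroxyl, or the opposite configuration at its carbon, would read.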